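A few compounds are considered here, and "the series" means these few. Any claim that something is new, unique, unknown or untested is made for them only; others in the source may bear on it.

Compound 1 `Cc1ccc2occ([C@@H]3C[C@H](c4ccccc4)ON3c3ccccc3)c(=O)c2c1` carries the shared core of this small set. In a functional assay on Caco-2 cells (Homo sapiens) for inhibition, read by sulforhodamine B assay, with a stated time of 48 h (a lower number here means a stronger inhibitor, a higher number a weaker inhibitor), compound 1 gives 31700 nM, the only numerical result among the two values recorded. Compound 2 `O=c1c([C@@H]2C[C@H](c3ccccc3)ON2c2ccccc2)coc2ccccc12` differs from compound 1 by hydrogen in place of methyl on an aromatic carbon. In this assay compound 2 gives > 60000 nM, which is a limit of the assay rather than a number. The step of an at least 1.8-fold higher number from compound 1 to compound 2 (0.27 log units; that floor lies within the scatter) is known only as a floor, one that lies within the usual scatter, and it rests on (the limit of > 60000 nM in this assay, at which 1 of the 2 values shown sits). Compound 3 `Cc1ccc2occ([C@@H]3C[C@H](OCC(C)C)ON3c3ccccc3)c(=O)c2c1` has not yet been measured. It differs from compound 1 by isobutoxy in place of phenyl on a saturated ring carbon. Among the measured compounds shown here, the single measured step concerns a methyl on an aromatic carbon, a different place from the saturated ring carbon changed here, so it offers no guidance on the direction or size of the change for compound 3. The estimated step of a 1.1-fold higher number from compound 1 to compound 3 (0.04 log units; within the scatter) is expected to stay near no change. Compound 3 is expected to give about 35000 nM in this assay, within a range from 8000 nM to 60000 nM.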

Compound 3, half-maximal inhibitory concentration: > 60000 nM
Compound 3: only a limit was reported (the forecaster's own chance of this, stated with the estimate: 40%); middle value at least 1.7-fold (0.23 log units) from the limit.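

Compound 3 is the first compound shown with a change on the saturated ring carbon next to the ring oxygen, and its result in this assay is a limit and not a number. Putting isobutoxy in place of phenyl there gives an at least 1.8-fold higher number from compound 1 to compound 3 (0.27 log units; that floor lies within the scatter), so the data fix only a floor for this change, and that floor does not separate the two compounds. The open chain, which has no ring and brings a hydrogen-bond acceptor, does not yield a numerical result at this position, and the changes at both places on compound 1 now end at the same limit, which leaves the true size of each step unknown: the limit of > 60000 nM in this assay, at which 2 of the 3 values shown sit.

The compounds shown leave open whether an amine, a carboxylic acid or a longer chain on this saturated ring carbon would give a result stronger than that of compound 1 at 31700 nM. They also leave open whether any group other than phenyl at this position, such as a methoxy group or a substituted phenyl, keeps a numerical result in this assay at all.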